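Cytotoxicity of Four Related Compounds on Vero Cells

The compounds below may be only part of what the source reports. "The series", "measured", "known", "first", "only" and "open" are said of these compounds alone.

Of the compounds shown here, three have been measured in an ADME assay on Vero cells (Chlorocebus sabaeus) for cytotoxicity, read by neutral red uptake, with a stated time of 48 h; a lower number here means a stronger inhibitor, a higher number a weaker inhibitor. Each of their values is a limit of the assay rather than a number:

Compound 1 `CN1CCN(c2nc(Cl)nc3c2ncn3CCNc2ccnc3cc(Cl)ccc23)CC1` gives > 10400 nM.
Compound 2 `CCN1CCN(c2nc(Cl)nc3c2ncn3CCNc2ccnc3cc(Cl)ccc23)CC1` gives > 10100 nM.
Compound 3 `CN1CCN(c2nc(Cl)nc3c2ncn3CCCNc2ccnc3cc(Cl)ccc23)CC1` gives > 10100 nM.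

Compound 2 differs from compound 1 by methyl in place of hydrogen on a saturated chain carbon bound to an amine nitrogen in a ring. In this assay the step is a step that the two limits leave unreadable from compound 1 to compound 2, since both values sit at limits and nothing more can be read from them.

Compound 3 carries a different core from compound 1, and the difference between the two cores is not broken down here. Compound 4 `CCN1CCN(c2nc(Cl)nc3c2ncn3CCCNc2ccnc3cc(Cl)ccc23)CC1` is built from compound 3 by methyl in place of hydrogen on a saturated chain carbon bound to an amine nitrogen in a ring, the same change as that from compound 1 to compound 2, at the same place in words.

Going by the values given here, for this assay the step from compound 3 to compound 4 is expected to be a step that the limit leaves unreadable from compound 3 to compound 4, because compound 3 sits at the limit of > 10100 nM in this assay, at which 2 of the 3 values shown sit, and the only measured example of this change left the value at a limit. Compound 4 is therefore estimated at 15000 nM, most likely reported as a limit again, with a range from 7000 nM to 40000 nM.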

Compound 4, half-maximal inhibitory concentration: > 9830 nM
Compound 4: no number, only a limit (the forecaster's own chance of this, stated with the estimate: 85%); the middle value is on the limit's open side.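

In this assay, compound 3 and compound 4 both give only a limit of the assay rather than a number, so the step between them cannot be read. The compounds shown leave open the concentration at which any of them would inhibit these cells by half, and whether the change from 4-methylpiperazin-1-yl to 4-ethylpiperazin-1-yl alters it.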